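The compounds below may be only part of what the source reports. "The series", "measured", "known", "first", "only" and "open" are said of these compounds alone.

Compound 1 `O=C(Nc1ccnnc1)c1cc(C(F)(F)F)ccc1OCc1ccccc1` gives 15.9 nM in an assay on Sf9 cells for inhibition of Leucine-rich repeat serine/threonine-protein kinase 2 (Homo sapiens), read by TR-FRET, with stated times of 30 min and 2 h; on this read-out higher numbers stand for weaker inhibition and lower numbers for stronger inhibition.
Compound 2 `O=C(Nc1ccnnc1)c1cc(N2C[C@H]3COC[C@H]3C2)ccc1OCc1ccccc1` gives 50.1 nM.
Compound 3 `CN1CCC(c2ccc(OCc3ccccc3)c(C(=O)Nc3ccnnc3)c2)CC1` gives 20 nM.

Among these three, compound 1 has the lowest number, though its gap to compound 3 lies within the usual scatter, so the two cannot be ranked; only compound 2 stands clearly apart, with the higher number.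

Compound 4 `O=C(Nc1cccnc1)c1cc(C(F)(F)F)ccc1OCc1ccccc1` is the unmeasured compound. It differs from compound 1 in one place: pyridin-3-yl in place of pyridazin-4-yl on an amide-type nitrogen. The rest of the shared core, the benzyloxy group and the trifluoromethyl group are kept.

Within the data shown here, none of the measured steps touches that part of the molecule. All three steps change the group on the aromatic carbon of the core and leave the ring on the amide nitrogen unchanged: a 3.2-fold higher number from compound 1 to compound 2 (0.50 log units; beyond the scatter), a 1.3-fold higher number from compound 1 to compound 3 (0.10 log units; within the scatter) and a 2.5-fold lower number from compound 2 to compound 3 (0.40 log units; beyond the scatter). They show that changes elsewhere move the number only modestly, but they give no direct guide for swapping pyridazin-4-yl for pyridin-3-yl. The estimate is therefore a step in this assay of no clear direction, likely within the scatter, with a wide range on both sides: a 1.6-fold higher number from compound 1 to compound 4 (0.20 log units; within the scatter) is the expected step. Compound 4 is expected to give about 25 nM, between 6 nM and 110 nM.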

Compound 4, half-maximal inhibitory concentration: 12.6 nM
Estimate against measurement, compound 4: 2.0-fold (0.30 log units) above; low and high end bracket the measured number.
By their numbers in this assay, from the lowest: compounds 4, 1 and 3 (each within the scatter of the next); then compound 2.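

Placing pyridin-3-yl instead of pyridazin-4-yl on the amide-type nitrogen gives a 1.3-fold lower number from compound 1 to compound 4 (0.10 log units; within the scatter) in this assay, the only reading shown so far for a change at this position. The step does not separate the two rings, so with the benzyloxy and trifluoromethyl groups kept, this pair gives no sign that the number depends on the second ring nitrogen of pyridazin-4-yl, even though the entering ring has one hydrogen-bond acceptor where the leaving ring has two. Nothing given here offers an explanation of why the two rings read alike.

As far as these compounds go, this ring change can be read only with trifluoromethyl on the core, so it remains open whether it would read the same alongside the 1-methylpiperidin-4-yl group of compound 3 or the group carried by compound 2. Also open, from the compounds shown here alone, is what a plain phenyl ring, with no ring nitrogen, would give on the amide-type nitrogen, which would show whether any ring nitrogen at this position matters for the number.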